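Aryl substituent exchange in the hindlimb series

The source may report more compounds than this note shows. Statements on the series, on what has been measured and on what is new or still open speak of the compounds shown alone.

Compound 2 `CC(C)(C)c1ccc(C(=O)NN2C(=O)NC3(CC3(C)C)C2=O)cc1` stands lowest of the three numbers in a functional assay on the whole organism (Hindlimb) for inhibition, with Mus musculus as the target, with a stated time of 0.5 h (on this read-out higher numbers stand for an effect only at larger amounts of compound and lower numbers for an effect already at smaller amounts), at 30 mg/kg. Compound 1 `Cc1cccc(C(=O)NN2C(=O)NC3(CC3(C)C)C2=O)c1` gives 100 mg/kg and compound 3 `CC1(C)CC12NC(=O)N(NC(=O)c1ccccc1F)C2=O` gives 100 mg/kg; the step of no change at the digits printed from compound 1 to compound 3 (within the scatter) shows no movement. Compound 4 `CC1(C)CC12NC(=O)N(NC(=O)c1ccc([N+](=O)[O-])cc1)C2=O` differs from compound 2 by nitro in place of tert-butyl on an aromatic carbon. Within the data shown here, no measured step exchanges a group at the place para to a large group, so the only measured step bears on it indirectly, as a sign that a different ring substituent left this assay flat between compound 1 and compound 3. Compound 4 is expected to give 100 mg/kg, with a range of 30 mg/kg to 300 mg/kg. This means an expected step of a 3.3-fold higher number from compound 2 to compound 4 (0.52 log units; beyond the scatter) back toward the two higher numbers.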

Compound 4, minimum effective dose: 300 mg/kg
The estimate for compound 4 lay 3.0-fold (0.48 log units) below the measured number, within the range that was stated.
By their numbers in this assay, from the lowest: compound 2; then compounds 1 and 3 (each within the scatter of the next); then compound 4.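

Exchange at the place para to a large group moves this assay clearly: nitro in place of tert-butyl gives a 10-fold higher number from compound 2 to compound 4 (1.00 log units; beyond the scatter), whereas the one earlier step gave no change at the digits printed from compound 1 to compound 3 (within the scatter). The group on this aromatic carbon therefore matters to the minimum effective dose, at least between these two groups. Nothing measured here bears on why the step has this size.

Only tert-butyl and nitro are shown at this place. Where an amine, a carboxylic acid or a longer alkyl chain would fall relative to them remains open.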